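Benzylamine in place of the pyridyl amide on the triazole core

A few compounds are considered here, and "the series" means these few. Any claim that something is new, unique, unknown or untested is made for them only; others in the source may bear on it.

Measured compounds:
compound 1 `COc1ccc(Cn2c(CCc3ccccc3)nnc2[C@H](NC(=O)C(C)(C)N)c2c[nH]c3ccccc23)c(OC)c1`, 60 nM
compound 2 `COc1ccc(Cn2c(CCc3ccccc3)nnc2[C@H](NC(=O)c2ccncc2)c2c[nH]c3ccccc23)c(OC)c1`, 58 nM
compound 3 `CCc1ccc(Cn2c(CCc3ccccc3)nnc2[C@H](NC(=O)c2ccncc2)c2c[nH]c3ccccc23)cc1`, > 1000 nM

In an in vitro assay on LLC-PK1 cells for displacement of a labelled ligand from growth hormone secretagogue receptor type 1 (Homo sapiens) (on this read-out higher numbers stand for weaker inhibition and lower numbers for stronger inhibition), compound 2 gives 58 nM. Of the two numbers shown, compound 2 and compound 1 lie within the scatter of each other, as the step of a 1.0-fold lower number from compound 1 to compound 2 (0.01 log units; within the scatter) shows. For compound 3 this assay reports only a limit, > 1000 nM. The step of an at least 17-fold higher number from compound 2 to compound 3 (1.23 log units; beyond the scatter) sits at the saturated chain carbon bound to an aromatic nitrogen, a different place from the one treated here.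

Compound 4 `COc1ccc(Cn2c(CCc3ccccc3)nnc2[C@H](NCc2ccccc2)c2c[nH]c3ccccc23)c(OC)c1` has not yet been measured. It differs from compound 2 as follows: benzyl in place of (pyridin-4-yl)carbonyl on an amine nitrogen. The step of a 1.0-fold lower number from compound 1 to compound 2 (0.01 log units; within the scatter) bears on this position and shows that exchanging the group on the carbonyl carbon left the number within the scatter. No measured step removes the carbonyl itself, so the effect of that change is not covered by the compounds shown. The author therefore expects a moderate loss, a 5.2-fold higher number from compound 2 to compound 4 (0.71 log units; beyond the scatter), with wide uncertainty in this assay. The estimate for compound 4 is 300 nM, expected to fall between 60 nM and 2000 nM.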

Compound 4, half-maximal inhibitory concentration: > 1000 nM
Compound 4 gave a limit, no number; the forecaster's own chance of this, stated with the estimate: 25%; middle value at least 3.3-fold (0.52 log units) from the limit.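

In this assay compound 4 gives only a limit of the assay, > 1000 nM. Exchanging the group on the carbonyl carbon had left the number within the scatter, but replacing the whole acyl group on the amine nitrogen with benzyl is a large loss from either amide, seen in the steps of an at least 17-fold higher number from compound 2 to compound 4 (1.23 log units; beyond the scatter) and an at least 16-fold higher number from compound 1 to compound 4 (1.22 log units; beyond the scatter). The position therefore accepts two very different groups on the carbonyl carbon yet not benzyl on the nitrogen, and the full size of this loss cannot be read from either step: the limit of > 1000 nM in this assay, at which 2 of the 4 values shown sit.

The change from (pyridin-4-yl)carbonyl to benzyl removes the carbonyl and also replaces the pyridine ring with a ring of carbon only, so the compounds shown do not separate these two changes; a benzoyl or a pyridin-4-ylmethyl group on the same nitrogen would tell them apart. Going by these compounds, it also remains open how the bare amine, or a short alkyl group such as methyl, would compare at this position.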